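Bromo to aminomethyl on the benzamide arm of compound 2

The source may hold more compounds than are shown below. What is called first, only, known or untested is meant among the compounds shown, and "the series" means these compounds.

The series shares a bis-amide-linked central ring and was run in an assay on isolated protein for inhibition of Rho-associated protein kinase 1 (Homo sapiens), read by scintillation counting, radiometric assay and 33P incorporation, with a stated time of 40 min, in the presence of a further agent that is not named here; a lower number here means a stronger inhibitor, a higher number a weaker inhibitor. Within the data shown here, compound 2 `O=C(COc1ccc2c(=O)ccoc2c1)Nc1cccc(NC(=O)c2ccc(Br)cc2)c1` gives 303 nM, the only number in the set. Compound 1 `COc1ccc(OCC(=O)Nc2cccc(NC(=O)c3ccc(N(C)C)cc3)c2)cc1OC` returns a limit of the assay, > 10000 nM. Compound 3 `O=C(COc1ccc2c(=O)ccoc2c1)Nc1cccc(NS(=O)(=O)c2ccc(C(F)(F)F)cc2)c1` likewise returns a limit, > 10000 nM. Among the measured compounds shown here, two of the three values thus sit at the limit (the limit of > 10000 nM in this assay, at which 2 of the 3 values shown sit), so compound 2 stands alone as the one compound with a measurable inhibition, and no step between measured compounds can be drawn.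

Compound 4 `NCc1ccc(C(=O)Nc2cccc(NC(=O)COc3ccc4c(=O)ccoc4c3)c2)cc1` has not yet been measured. It differs from compound 2 only in the group on the benzamide ring: aminomethyl in place of bromo on an aromatic carbon.

For the measured compounds named here, with no measured step in this direction, the expectation rests on compound 2 alone. The change is expected to leave the inhibition of compound 4 within a modest distance of compound 2, with a slight lean toward a stronger value rather than a weaker one. The step from compound 2 to compound 4 is estimated as a 2.0-fold lower number from compound 2 to compound 4 (0.31 log units; beyond the scatter). Compound 4 is expected to give about 150 nM, with a range from 40 nM to 600 nM.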

Compound 4, half-maximal inhibitory concentration: 532 nM
Estimate against measurement, compound 4: 3.5-fold (0.55 log units) below, within the range that was stated.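

In this assay, aminomethyl in place of bromo on an aromatic carbon gives a 1.8-fold higher number from compound 2 to compound 4 (0.24 log units; within the scatter), so the two groups cannot be told apart at this position. Compound 4 supplies the second number in the series and shows that measurable inhibition does not depend on bromo: the 4-bromophenyl can become 4-(aminomethyl)phenyl, with the hydrogen-bond donor and acceptor the new group adds, without a change beyond the scatter. Compound 1 and compound 3 each differ from compound 2 in more than one place and each remains at a limit of the assay, so no step to either can be read and this one pair carries all that is known about the position: the limit of > 10000 nM in this assay, at which 2 of the 4 values shown sit.

As far as these compounds go, with only bromo and aminomethyl compared here, it remains open whether a carboxylic acid, a longer chain such as aminoethyl, or plain hydrogen at this position would also stay within the scatter of compound 2. Among these compounds, the separate contributions of the chromone-free aryloxy arm and the sulfonamide link also remain open, as no single-place pair isolates either one.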